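Fluoro to phenyl: the step from compound 2

A few compounds are considered here, and "the series" means these few. Any claim that something is new, unique, unknown or untested is made for them only; others in the source may bear on it.

In a functional assay on KB cells (Homo sapiens) for antiproliferative activity, read by colorimetric assay and MTT assay (on this read-out higher numbers stand for weaker inhibition and lower numbers for stronger inhibition), compound 1 `O=S(=O)(Nc1ccc(Cl)c2cc[nH]c12)c1ccc(Cl)cc1` gives 9.7 ug/mL and compound 2 `Nc1ccc(S(=O)(=O)Nc2ccc(F)c3c(Cl)c[nH]c23)cc1` gives 14 ug/mL, two values within the scatter of each other. Compound 3 `Nc1ccc(S(=O)(=O)Nc2ccc(-c3ccccc3)c3c(Cl)c[nH]c23)cc1` carries phenyl in place of fluoro on an aromatic carbon, para to a large group: phenyl in place of fluoro on an aromatic carbon. Among the measured compounds shown here, no measured pair shows a change at one place, so the expectation rests on the structural change alone. The moderate shift toward stronger inhibition expected in this assay is estimated to be a 1.8-fold lower number from compound 2 to compound 3 (0.24 log units; within the scatter). Compound 3 is estimated at 8 ug/mL, with an expected range of 2.5 ug/mL to 25 ug/mL.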

Compound 3, half-maximal inhibitory concentration: 15 ug/mL
For compound 3 the middle estimate is 1.9-fold (0.27 log units) below the measured one; low and high end bracket the measured number.
By their numbers in this assay, from the lowest: compounds 1, 2 and 3 (each within the scatter of the next).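

In this assay, phenyl in place of fluoro on an aromatic carbon, para to a large group, gives a 1.1-fold higher number from compound 2 to compound 3 (0.03 log units; within the scatter). This position therefore accepts a six-membered aromatic ring of carbon only in place of a single fluorine, and the read-out does not separate the two groups. No measurement at hand offers an explanation for this result.

On these data alone, whether an amine or a carboxylic acid at this position would separate from fluoro and phenyl remains open. As far as these compounds go, with a single step at this position, it is also open whether the same exchange would read alike on another core.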